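Isopropyl for cyclohexyl on the amide of compound 2

This account rests on a few compounds, and the source may have more. Where it says the series, first, only, none or still open, it means among the compounds named here.

Compound 1 `COC(=O)/C=C/c1cccc(N(Cc2ccc(/C=C/c3cccc(C(F)(F)F)c3)cc2)C(=O)C(C)C)c1` in an assay on isolated protein with Bile acid receptor (Homo sapiens) as the target; on this read-out lower numbers stand for an effect already at smaller amounts and higher numbers for an effect only at larger amounts of compound: 267 nM
Compound 2 `COC(=O)/C=C/c1cccc(N(Cc2ccc(-c3cccc(Cl)c3)cc2)C(=O)C2CCCCC2)c1` in this assay: 94 nM

Compound 2 holds the lower of the two values; compound 1 lies higher by a margin beyond the usual scatter. Compound 3 `COC(=O)/C=C/c1cccc(N(Cc2ccc(-c3cccc(Cl)c3)cc2)C(=O)C(C)C)c1` carries isopropyl in place of cyclohexyl on a carbonyl carbon. Among the compounds with values here, no pair of measured compounds isolates this change, since compound 1 and compound 2 differ in more than one place. A step beyond the scatter is not expected from compound 2 to compound 3, although a small upward drift is estimated as a 1.8-fold higher number from compound 2 to compound 3 (0.26 log units; within the scatter). Compound 3 is therefore expected at 170 nM, within 60 nM to 500 nM.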

Compound 3, half-maximal effective concentration: 77 nM
Beside the measured number, compound 3's estimate is 2.2-fold (0.34 log units) above it; measured number inside the range.
By their numbers in this assay, from the lowest: compounds 3 and 2 (each within the scatter of the next); then compound 1.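

In this assay, the carbonyl carbon of the amide accepts isopropyl in place of cyclohexyl with a 1.2-fold lower number from compound 2 to compound 3 (0.09 log units; within the scatter), so the cyclohexyl ring is not required there for this read-out. With isopropyl held constant, 3-chlorophenyl in place of 2-(3-(trifluoromethyl)phenyl)ethenyl on an aromatic carbon gives a 3.5-fold lower number from compound 1 to compound 3 (0.54 log units; beyond the scatter), which shows that this other position affects the number more. No available measurement explains either step. On these data alone, whether an amine or a longer chain on that carbonyl carbon would keep the number within the scatter remains open.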